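This account rests on a few compounds, and the source may have more. Where it says the series, first, only, none or still open, it means among the compounds named here.

Compound 1 `COc1cc(/C=C2\CN(C)C/C(=C\c3ccccc3F)C2=O)cc(OC)c1OC` gives 640 nM in the series
Compound 2 `COc1cc(/C=C2\CN(C)C/C(=C\c3ccc(F)cc3)C2=O)cc(OC)c1OC` gives 6130 nM in the series
Compound 3 `COc1cc(/C=C2\CN(C)C/C(=C\c3ccc(Br)cc3)C2=O)cc(OC)c1OC` gives 5330 nM in the series
Compound 4 `COc1cc(/C=C2\CN(C)C/C(=C\c3cccc([N+](=O)[O-])c3)C2=O)cc(OC)c1OC` has no measurement yet

In a functional assay on THP-1 cells (Homo sapiens) for cytotoxicity, read by MTT assay, with a stated time of 24 h (a higher number here means a weaker inhibitor, a lower number a stronger inhibitor), compound 3 stands level with compound 2, since a 1.2-fold lower number from compound 2 to compound 3 (0.06 log units; within the scatter) is a step within the scatter. Both lie well above compound 1, and a 9.6-fold higher number from compound 1 to compound 2 (0.98 log units; beyond the scatter) and an 8.3-fold higher number from compound 1 to compound 3 (0.92 log units; beyond the scatter) are modest steps beyond the scatter.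

The change 3-nitrophenyl in place of 4-bromophenyl on a double-bonded chain carbon bound to a double-bonded ring carbon puts 3-nitrophenyl in place of 4-bromophenyl on a double-bonded chain carbon bound to a double-bonded ring carbon. For the measured compounds named here, no measured compound carries 3-nitrophenyl, so no measured step bears on it directly. The nearest guides are the same-place swaps: a 1.2-fold lower number from compound 2 to compound 3 (0.06 log units; within the scatter) shows that a swap here can leave the number unmoved, while an 8.3-fold higher number from compound 1 to compound 3 (0.92 log units; beyond the scatter) shows that one can move it clearly. No step beyond the scatter is therefore expected in this assay, with a slight lean towards a lower number and a wide margin. The estimated step is a 1.8-fold lower number from compound 3 to compound 4 (0.25 log units; within the scatter) and it stays within the scatter. For compound 4 the expected value is 3000 nM with an estimated range of 900 nM to 9000 nM in this read-out.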

Compound 4, half-maximal inhibitory concentration: 890 nM
Beside the measured number, compound 4's estimate is 3.4-fold (0.53 log units) above it; the whole stated range lies above it.
By their numbers in this assay, from the lowest: compounds 1 and 4 (each within the scatter of the next); then compounds 3 and 2 (each within the scatter of the next).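

At the double-bonded chain carbon bound to a double-bonded ring carbon, this assay now shows a 6.0-fold lower number from compound 3 to compound 4 (0.78 log units; beyond the scatter) and a 6.9-fold lower number from compound 2 to compound 4 (0.84 log units; beyond the scatter), while a 1.4-fold higher number from compound 1 to compound 4 (0.14 log units; within the scatter) leaves compound 4 level with compound 1. The low end of the series is therefore not tied to 2-fluorophenyl alone, since 3-nitrophenyl, a different group, stands level with it and clearly apart from both 4-fluorophenyl and 4-bromophenyl. Nothing among the data offered here accounts for this shift.

These four compounds change the substituent and its place on the phenyl ring together, so the contribution of each remains unresolved. Also open, from the compounds shown here alone, is whether an amine or a carboxylic acid in place of the nitro group of 3-nitrophenyl would keep the number at this level.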